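Removing one fluoro from compound 2: expected outcome

The compounds below may be only part of what the source reports. "The series", "measured", "known", "first", "only" and "open" are said of these compounds alone.

Measured so far in an assay on Sf9 cells for inhibition of protein deacetylase HDAC6 (Homo sapiens), read by fluorescence; a higher number here means a weaker inhibitor, a lower number a stronger inhibitor:
- compound 1, `Cc1ccc(C(=O)NO)cn1`, 70 nM
- compound 2, `Nc1c(F)cc(C(=O)NO)cc1F`, 112 nM
- compound 3, `Cc1c(F)cc(C(=O)NO)cc1F`, 27 nM

Compound 2 gives the highest of the three numbers in this assay. Its nearest neighbour is compound 1, whose value sits within the scatter of it; the furthest is compound 3, reached by a 4.1-fold lower number from compound 2 to compound 3 (0.62 log units; beyond the scatter), a modest step beyond the scatter.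

Compound 4, `Nc1ccc(C(=O)NO)cc1F`, differs from compound 2 by hydrogen in place of fluoro on an aromatic carbon. Going by the values given here, none of the measured steps covers this change: the only step in hand swaps methyl for amino, not fluoro for hydrogen. Compound 1 carries no fluoro and compound 3 carries two, but they also differ in other ways from compound 2 and from each other, so their values say nothing clean about the fluoro alone. The expectation for compound 4 in this assay is therefore a step no larger than the scatter, in no firm direction; the estimate is 130 nM, between 50 nM and 350 nM, corresponding to a 1.2-fold higher number from compound 2 to compound 4 (0.06 log units; within the scatter).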

Compound 4, half-maximal inhibitory concentration: 183 nM
For compound 4 the middle estimate is 1.4-fold (0.15 log units) below the measured one; low and high end bracket the measured number.
By their numbers in this assay, from the lowest: compound 3; then compounds 1, 2 and 4 (each within the scatter of the next, the first and the last beyond it).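

In this assay hydrogen in place of the fluoro ortho to an amino group gives a 1.6-fold higher number from compound 2 to compound 4 (0.21 log units; within the scatter) and so stays within the scatter. Going by these compounds alone, this is the first direct reading of the fluoro at this position, since the earlier step, a 4.1-fold lower number from compound 2 to compound 3 (0.62 log units; beyond the scatter), concerned the amino group and left both fluoro groups in place. With the amino group kept, one fluoro can therefore go without a difference that can be told from the scatter, and nothing at hand gives a reason for this.

Still open, on these data alone, is whether the same swap reads alike when methyl stands in place of amino, and what the loss of both fluoro groups does. Also open, as far as these compounds go, is how a chlorine atom or a methoxy group would read on this aromatic carbon.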